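Swapping phenoxy for (pyridin-2-yl)amino on the shared core

The compounds below may be only part of what the source reports. "The series", "measured", "known", "first", "only" and "open" are said of these compounds alone.

In an ADME assay (liver) for metabolic stability, with Liver microsome (Rattus norvegicus) as the target, using microsomes and NADPH, with a stated time of 30 min, at 37 degrees C, tested at 1 uM (on this read-out higher numbers stand for fast clearance and lower numbers for slow clearance), compound 1 `CNc1nc(S(=O)(=O)c2ccc(N)nc2)ccc1-c1ccc(C(C)(O)C(F)(F)F)cn1` gives 21 mL.min-1.g-1 and compound 2 `CC(O)(c1ccc(-c2ccc(S(=O)(=O)c3ccc(N)nc3)nc2Nc2ccccc2)nc1)C(F)(F)F` gives 100 mL.min-1.g-1, while compound 3 `CC(O)(c1ccc(-c2ccc(S(=O)(=O)c3ccc(N)nc3)nc2Oc2ccccc2)nc1)C(F)(F)F` stands highest of the three at 213 mL.min-1.g-1 on this read-out. Compound 4 `CC(O)(c1ccc(-c2ccc(S(=O)(=O)c3ccc(N)nc3)nc2Nc2ccccn2)nc1)C(F)(F)F` has (pyridin-2-yl)amino in place of phenoxy on an aromatic carbon and is still to be measured.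

The measured step closest to this change is a modest one (a 2.1-fold higher number from compound 2 to compound 3 (0.33 log units; beyond the scatter)) with phenoxy in place of anilino, and compound 4 runs the opposite way, from phenoxy back to an amino link. The modest step (a 4.8-fold higher number from compound 1 to compound 2 (0.68 log units; beyond the scatter)) and the large step (a 10-fold higher number from compound 1 to compound 3 (1.01 log units; beyond the scatter)) both start from methylamino and say less about this change. Within the data shown here, no measured compound has a ring nitrogen in this group, so that part of the change stays open.

A modest step to a lower number is therefore expected in this assay for this change. The estimated step is a 2.5-fold lower number from compound 3 to compound 4 (0.40 log units; beyond the scatter) as expected here. Compound 4 is estimated at 85 mL.min-1.g-1 with an expected range of 30 mL.min-1.g-1 to 210 mL.min-1.g-1 in this assay.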

Compound 4, intrinsic clearance in microsomes: 130 mL.min-1.g-1
For compound 4 the middle estimate is 1.5-fold (0.18 log units) below the measured one; low and high end bracket the measured number.
By their numbers in this assay, from the lowest: compound 1; then compounds 2, 4 and 3 (each within the scatter of the next, the first and the last beyond it).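

In this assay the (pyridin-2-yl)amino group on this aromatic carbon, next to the ring nitrogen, cannot be told apart from phenoxy (a 1.6-fold lower number from compound 3 to compound 4 (0.21 log units; within the scatter)) or from the anilino group, which differs from it only by the ring nitrogen (a 1.3-fold higher number from compound 2 to compound 4 (0.11 log units; within the scatter)), so this first ring nitrogen in the group gives no readable shift from anilino. Methylamino still stands apart (a 6.2-fold higher number from compound 1 to compound 4 (0.79 log units; beyond the scatter)), and compound 1 now has a number lower beyond the scatter than all three compounds carrying a six-membered aromatic ring at this position. No measurement shown here accounts for these numbers.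

Going by these compounds, whether an ethylamino or cyclopropylamino group would read with methylamino or with the ring-bearing groups stays open. So does the effect of moving the ring nitrogen, as in a (pyridin-3-yl)amino group.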